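The compounds below may be only part of what the source reports. "The series", "measured", "known", "first", "only" and "open" are said of these compounds alone.

Of the compounds shown here, three sharing one core have been tested in an ADME assay on MRC5 cells (Homo sapiens), read by MTT assay, with a stated time of 3 days; on this read-out lower numbers stand for stronger inhibition and higher numbers for weaker inhibition. Compound 1 `Nc1ncnc2[nH]cc(Sc3cccs3)c12`, with an amino group, gives 136000 nM. Compound 2 `c1csc(Sc2c[nH]c3ncnc(-c4cccs4)c23)c1`, with thiophen-2-yl in that place, gives 54500 nM, and compound 3 `c1coc(-c2ncnc3[nH]cc(Sc4cccs4)c23)c1`, with furan-2-yl there, gives 32900 nM. Compound 2 therefore shares the low end of these numbers with compound 3, and compound 1 stands clearly above both.

Compound 4 `COc1ncnc2[nH]cc(Sc3cccs3)c12` has not been measured yet. Its change from compound 2 is methoxy in place of thiophen-2-yl on an aromatic carbon, which is methoxy in place of thiophen-2-yl on an aromatic carbon.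

Among the compounds with values here, no methoxy compound has been measured, so the nearest guide is the same place in the other compounds. Replacing amino with thiophen-2-yl gave a 2.5-fold lower number from compound 1 to compound 2 (0.40 log units; beyond the scatter), and replacing amino with furan-2-yl gave a 4.1-fold lower number from compound 1 to compound 3 (0.62 log units; beyond the scatter). Both steps are modest but beyond the scatter. Replacing thiophen-2-yl with furan-2-yl gave a 1.7-fold lower number from compound 2 to compound 3 (0.22 log units; within the scatter), which is within the scatter. Methoxy has no ring, and neither has the amino group of compound 1, which gives 136000 nM. A small move back toward that number is therefore expected in this assay. The expected step is a 1.6-fold higher number from compound 2 to compound 4 (0.19 log units; within the scatter), possibly no larger than the scatter. For compound 4 the estimated value is 85000 nM, with an expected range from 35000 nM to 200000 nM.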

Compound 4, half-maximal inhibitory concentration: 148000 nM
Compound 4: the middle estimate sits 1.7-fold (0.24 log units) below what was measured; low and high end bracket the measured number.
By their numbers in this assay, from the lowest: compounds 3 and 2 (each within the scatter of the next); then compounds 1 and 4 (each within the scatter of the next).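

In this assay, methoxy lands with the amino group and not with the two ring groups: a 1.1-fold higher number from compound 1 to compound 4 (0.04 log units; within the scatter), so these two compounds cannot be told apart, while a 2.7-fold higher number from compound 2 to compound 4 (0.43 log units; beyond the scatter) and a 4.5-fold higher number from compound 3 to compound 4 (0.65 log units; beyond the scatter). Across these four compounds the numbers therefore fall into two sets, with thiophen-2-yl and furan-2-yl, which each bring a five-membered aromatic ring to this place on the shared core, giving the lower numbers, and methoxy and amino, which bring no ring, giving the higher ones; no compound shown goes against this split. This also shows that swapping one ringless group for another at this place leaves the number unchanged within the scatter, though no measurement in hand gives a reason for the split.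

On these data alone, the two ring groups are also the larger groups here, so it stays open whether the ring itself or simply the size of the group goes with the lower numbers. A longer chain without a ring, such as butoxy, set against a phenyl ring at the same place, would pull those two readings apart.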